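Removing the methoxy group from compound 2

This account rests on a few compounds, and the source may have more. Where it says the series, first, only, none or still open, it means among the compounds named here.

Compound 2 `COc1ccc(-c2cc(=O)n3nc(-c4ccccc4)cc3[nH]2)cc1` carries a methoxyphenyl group and a phenyl substituent on the shared core. In a functional assay on U-251 cells (Homo sapiens) for cytotoxicity, read by resazurin assay, with stated times of 30 s and 48 h (on this read-out lower numbers stand for stronger inhibition and higher numbers for weaker inhibition), compound 2 gives 5670000 nM, the highest of the two numbers measured, while compound 1 `COc1ccc(-c2cc(=O)n3nc(C(C)C)cc3[nH]2)cc1` gives 127000 nM. Among the measured compounds shown here, the only measured step, a 45-fold higher number from compound 1 to compound 2 (1.65 log units; beyond the scatter), concerns the isopropyl-to-phenyl exchange and not the methoxyphenyl part.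

Compound 3 `O=c1cc(-c2ccccc2)[nH]c2cc(-c3ccccc3)nn12` differs from compound 2 in one place: hydrogen in place of methoxy on an aromatic carbon. For the measured compounds named here, no measured step touches this position, so there is nothing in the data to indicate a direction for the change. The expectation therefore rests on compound 2 alone, which in this assay gives 5670000 nM. Compound 3 is expected to stay close to that number, with a step of a 1.1-fold higher number from compound 2 to compound 3 (0.02 log units; within the scatter) that is estimated to lie within the scatter. For compound 3 the estimate in this assay is 6000000 nM, with a range from 1500000 nM to 25000000 nM; given how weak compound 2 already is, the assay may report only a limit for compound 3.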

Compound 3, half-maximal inhibitory concentration: 73600 nM
Compound 3: the middle estimate sits 82-fold (1.91 log units) above what was measured; the whole stated range lies above it.
By their numbers in this assay, from the lowest: compounds 3 and 1 (each within the scatter of the next); then compound 2.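

The position on the six-membered aromatic ring of carbon only, para to a large group, turns out to be far from silent: in this assay, the exchange of methoxy for hydrogen gives a 77-fold lower number from compound 2 to compound 3 (1.89 log units; beyond the scatter). Among the compounds shown here, until now the only measured change was at the other substituent of the shared core, a 45-fold higher number from compound 1 to compound 2 (1.65 log units; beyond the scatter), and this second step shows that the number also responds strongly to the 4-methoxyphenyl to phenyl change, so both places matter in the phenyl-bearing series, with each step lying beyond the scatter. Nothing available here accounts for the size or direction of this step.

The compounds shown leave open whether the same change would have a comparable effect with the isopropyl group of compound 1 in place, since this step has been read against the phenyl substituent of compound 2 alone. They also leave open how the number would respond at this place to a group other than methoxy or hydrogen, such as a hydroxyl, an amine or a carboxylic acid.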